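Swapping a fluorophenyl ester for an acetate

A few compounds are considered here, and "the series" means these few. Any claim that something is new, unique, unknown or untested is made for them only; others in the source may bear on it.

Of the compounds shown here, three sharing one core have been measured in an ADME assay on cells (Hepatocyte, Mus musculus) for metabolic stability, with a stated time of 30 min; on this read-out higher numbers stand for a more stable compound and lower numbers for a less stable compound. Compound 1 `Nc1cc(C(F)(F)F)cc2c(=O)cc(N3CCN(CC4CCCCC4)CC3)sc12` gives 69.4%. Compound 2 `CC(=O)NC1CCC(CN2CCN(c3cc(=O)c4cc(C(F)(F)F)cc([N+](=O)[O-])c4s3)CC2)CC1` gives 94.9%. Compound 3 `O=C(OC1CCC(CN2CCN(c3cc(=O)c4cc(C(F)(F)F)cc([N+](=O)[O-])c4s3)CC2)CC1)c1ccc(F)cc1` gives 1.5%, the lowest of the three values, separated from both others by more than the usual scatter.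

Compound 4 `CC(=O)OC1CCC(CN2CCN(c3cc(=O)c4cc(C(F)(F)F)cc([N+](=O)[O-])c4s3)CC2)CC1` is not yet measured. Its structure differs from compound 3 in one place: methyl in place of 4-fluorophenyl on a carbonyl carbon. Read one bond further out, the change is (4-fluorophenyl)carbonyl to acetyl.

Among the compounds with values here, the only measured step that bears on this change is a number 93.4 percentage points lower from compound 2 to compound 3 (beyond the scatter). That step swapped acetamido for ((4-fluorophenyl)carbonyl)oxy, so it combined two changes at once; compound 4 reverses only the part concerning the 4-fluorophenyl. Within the data shown here, a rise in this assay is therefore expected, though smaller than the full step and with wide uncertainty, since no measured pair isolates this exact exchange. For compound 4 the expected value is 35%, with a range from 5% to 80%, meaning an expected step of a number 33.5 percentage points higher from compound 3 to compound 4 (beyond the scatter).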

Compound 4, percent of the compound remaining: 0%
For compound 4 the middle estimate is 35 percentage points above the measured one; the whole stated range lies above it.
By their numbers in this assay, from the lowest: compounds 4 and 3 (each within the scatter of the next); then compound 1; then compound 2.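

Exchanging 4-fluorophenyl for methyl on the carbonyl carbon gives a number 1.5 percentage points lower from compound 3 to compound 4 (within the scatter) in this assay, so in this pair the size of that group makes no readable difference. The change that does register is acetoxy in place of acetamido on the saturated ring carbon, with a number 94.9 percentage points lower from compound 2 to compound 4 (beyond the scatter) as a clean one-place comparison. The earlier large step mixed two changes, and this result places the whole of the gap on the side of that swap, with the aryl group contributing nothing that can be read.

On these data alone, how a hydroxyl group, an amine or a carboxylic acid on that saturated ring carbon would read in this assay remains open. Nothing measured here gives the reason for these numbers.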